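Fluoromethyl to methoxymethyl on a shared core

A few compounds are considered here, and "the series" means these few. Any claim that something is new, unique, unknown or untested is made for them only; others in the source may bear on it.

Going by the values given here, in a functional assay on HeLa cells (Homo sapiens) for cytotoxicity, read by WST assay, with a stated time of 48 h (a higher number here means a weaker inhibitor, a lower number a stronger inhibitor), compound 1 `COC[C@H](C)[C@H](C)C(c1ccc(O)c(OC)c1)c1ccc(O)c(OC)c1` gives 72000 nM and compound 2 `COc1cc(C(c2ccc(O)c(OC)c2)[C@H](C)[C@H](C)CF)ccc1O` gives 75000 nM, so compound 2 stands level with the only other measured compound. Compound 3 `COC[C@@H](C)[C@H](C)C(c1ccc(O)c(OC)c1)c1ccc(O)c(OC)c1` is reached from compound 2 with 2-(methoxymethyl)-1-methylpropyl in place of 2-(fluoromethyl)-1-methylpropyl on a saturated chain carbon bound to two aromatic carbons. Among the compounds with values here, the one measured step bearing on this is a 1.0-fold higher number from compound 1 to compound 2 (0.02 log units; within the scatter), an exchange of the same two groups run the opposite way. Within the data shown here, no measured step here concerns a change in the defined stereocentres, and the range is kept wide enough to allow for that. The expected step in this assay is accordingly none beyond the scatter, estimated as a 1.1-fold lower number from compound 2 to compound 3 (0.03 log units; within the scatter). For compound 3 the estimated value is 70000 nM, with an expected range from 40000 nM to 120000 nM.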

Compound 3, half-maximal inhibitory concentration: 58000 nM
Estimate against measurement, compound 3: 1.2-fold (0.08 log units) above; low and high end bracket the measured number.
By their numbers in this assay, from the lowest: compounds 3, 1 and 2 (each within the scatter of the next).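

Going by these compounds alone, compound 3 gives the first reading on configuration in this chain: in this assay, inverting one stereocentre at a saturated chain carbon gives a 1.2-fold lower number from compound 1 to compound 3 (0.09 log units; within the scatter), so among compounds 1 and 3 this inversion makes no difference beyond the scatter. The exchange of 2-(fluoromethyl)-1-methylpropyl for 2-(methoxymethyl)-1-methylpropyl also stays within the scatter in this second reading, with a 1.3-fold lower number from compound 2 to compound 3 (0.11 log units; within the scatter). Of these two steps, only the first isolates configuration alone: the fact that compounds 1 and 3 differ only in the configuration as drawn

The compounds shown leave open whether a chain ending in an amine or a carboxylic acid, or a longer chain, on the saturated chain carbon bound to two aromatic carbons would move the number beyond the scatter. Also open, as far as these compounds go, is the second defined stereocentre, which is drawn the same in compounds 1 and 3.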